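This account rests on a few compounds, and the source may have more. Where it says the series, first, only, none or still open, it means among the compounds named here.

Of the compounds shown here, three of a shared core have been measured in an assay on isolated protein with malate dehydrogenase, mitochondrial (Sus scrofa) as the target; a lower number here means a stronger inhibitor, a higher number a weaker inhibitor. Compound 1 `O=C(O)c1cnc2cc(S(=O)(=O)O)ccc2c1O` gives 2140000 nM. Compound 3 `O=C(O)c1cnc2cc(O)ccc2c1O` gives 490000 nM, and the step from compound 1 to compound 3, hydroxy in place of sulfo on an aromatic carbon, is a 4.4-fold lower number from compound 1 to compound 3 (0.64 log units; beyond the scatter). Compound 2 `O=C(O)c1cnc2cc(OCCc3ccc(Br)cc3)ccc2c1O` gives 2510 nM, the lowest number of the three; its values and those of compound 3 and compound 1 stand far apart.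

Compound 4 `O=C(O)c1cnc2cc(OCCOc3ccc(Br)cc3)ccc2c1O` differs from compound 2 by a single change: 4-bromophenoxy in place of 4-bromophenyl on a saturated chain carbon, two bonds along the chain from an oxygen on an aromatic ring. For the measured compounds named here, no measured step of this set bears directly on this change; the one step known, from compound 1 to compound 3, concerns a substituent on an aromatic carbon and not the saturated chain, so it offers no guide beyond the scatter. Going by the values given here, with no relevant precedent, the step of a 1.0-fold lower number from compound 2 to compound 4 (0.00 log units; within the scatter) is expected to stay within the usual scatter. Compound 4 is therefore estimated to give 2500 nM in this assay, with a range from 800 nM to 8000 nM.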

Compound 4, half-maximal inhibitory concentration: 5130 nM
Compound 4: the middle estimate sits 2.1-fold (0.31 log units) below what was measured, within the range that was stated.
By their numbers in this assay, from the lowest: compound 2; then compound 4; then compound 3; then compound 1.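

In this assay, for the compounds shown here, the step of a 2.0-fold higher number from compound 2 to compound 4 (0.31 log units; beyond the scatter) is the first reading at this saturated chain position, since the earlier step concerned only a substituent on an aromatic carbon. It shows that 4-bromophenoxy in place of 4-bromophenyl, a change that brings in one more heavy atom and one hydrogen-bond acceptor, costs only a modest amount, and the measured number of compound 4 stays at 5130 nM. Nothing available explains this shift.

The compounds shown leave open how much the bromine itself contributes, as a chlorine or an unsubstituted phenyl at the end of the chain would test. They also leave open whether a longer chain, or an amine in place of the oxygen that enters with 4-bromophenoxy, would lower or raise the number.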